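The source may hold more compounds than are shown below. What is called first, only, known or untested is meant among the compounds shown, and "the series" means these compounds.

Measured so far in a functional assay on A549 cells (Homo sapiens) for antiproliferative activity, read by MTT assay, with a stated time of 72 h; a lower number here means a stronger inhibitor, a higher number a weaker inhibitor:
Compound 1, `O=C(Nc1cccc(Br)c1)C(Cl)Cl`: 7800 nM
Compound 2, `O=C(Nc1cccc(I)c1)C(Cl)Cl`: 4760 nM
Compound 3, `N#Cc1cccc(NC(=O)C(Cl)Cl)c1`: 66500 nM

Compound 3 gives the highest number of the three, making it the weakest inhibitor among them. Compound 4, `O=C(Nc1cccc(SC(F)(F)F)c1)C(Cl)Cl`, differs from compound 3 by one change: (trifluoromethyl)sulfanyl in place of cyano on an aromatic carbon. For the measured compounds named here, no measured step involves the entering group, so the steps that bear on it are those in which cyano arrived, an 8.5-fold higher number from compound 1 to compound 3 (0.93 log units; beyond the scatter) and a 14-fold higher number from compound 2 to compound 3 (1.15 log units; beyond the scatter), both beyond the scatter and both pointing the same way. Removing cyano again is therefore expected to reverse that loss, giving a large drop in the number, a 19-fold lower number from compound 3 to compound 4 (1.28 log units; beyond the scatter). Compound 4 is estimated at 3500 nM, with a range from 1000 nM to 12000 nM.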

Compound 4, half-maximal inhibitory concentration: 14100 nM
The estimate for compound 4 lay 4.0-fold (0.61 log units) below the measured number, outside the stated range (above it).
By their numbers in this assay, from the lowest: compounds 2, 1 and 4 (each within the scatter of the next, the first and the last beyond it); then compound 3.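

In this assay, for the compounds shown here, replacing cyano with (trifluoromethyl)sulfanyl gives a 4.7-fold lower number from compound 3 to compound 4 (0.67 log units; beyond the scatter), so cyano is not the only group that differs sharply from the halogens at this position, yet the new group recovers only part of the gap. Iodo still gives the lower number, with a 3.0-fold higher number from compound 2 to compound 4 (0.47 log units; beyond the scatter), whereas bromo cannot be told apart from the new group, with a 1.8-fold higher number from compound 1 to compound 4 (0.26 log units; within the scatter), which lies within the scatter. Nothing measured here explains these differences. Going by these compounds, how an amine, a carboxylic acid or a longer alkyl chain would compare at this position remains open.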